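Swapping the sulfamide for a succinimide on the piperidine

The compounds below may be only part of what the source reports. "The series", "measured", "known", "first", "only" and "open" are said of these compounds alone.

Of the compounds shown here, two have been measured in an assay on CHO-K1 cells for displacement of a labelled ligand from melanin-concentrating hormone receptor 1 (Homo sapiens), read by scintillation proximity assay, with a stated time of 2 h; on this read-out higher numbers stand for weaker inhibition and lower numbers for stronger inhibition. Compound 1 `Cc1nc(N2CCC(NS(=O)(=O)N(C)C)CC2)nc2ccc(NC(=O)/C=C/c3ccc(OC(F)(F)F)cc3)cc12` gives 105 nM in this assay, the lower of the two numbers. Compound 2 `Cc1nc(N2CCC(O)(C3CC3)CC2)nc2ccc(NC(=O)/C=C/c3ccc(Cl)cc3Cl)cc12` differs from compound 1 in several places. In this assay compound 2 gives 620 nM, a higher number that lies beyond the scatter of the method, so compound 1 is the stronger of the measured pair.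

Compound 3 `Cc1nc(N2CCC(N3C(=O)CCC3=O)CC2)nc2ccc(NC(=O)/C=C/c3ccc(OC(F)(F)F)cc3)cc12` has not been measured. It differs from compound 1 in one place: 2,5-dioxopyrrolidin-1-yl in place of (dimethylsulfamoyl)amino on a saturated ring carbon. No comparable single change has been measured in this set, so the effect of exchanging a hydrogen-bond donor for a ring bearing two carbonyls cannot be read from the data. In this assay the step is expected to be a 2.1-fold higher number from compound 1 to compound 3 (0.32 log units; beyond the scatter), a modest move towards weaker binding. Compound 3 is therefore estimated at 220 nM in this assay, with a range from 60 nM to 800 nM.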

Compound 3, half-maximal inhibitory concentration: 94 nM
For compound 3 the middle estimate is 2.3-fold (0.37 log units) above the measured one; the measured number falls inside the stated range.
By their numbers in this assay, from the lowest: compounds 3 and 1 (each within the scatter of the next); then compound 2.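

Among the compounds shown here, the step of a 1.1-fold lower number from compound 1 to compound 3 (0.05 log units; within the scatter) in this assay is the first measured change at this saturated ring carbon, and it shows that the two groups cannot be told apart here. The hydrogen-bond donor counted in (dimethylsulfamoyl)amino is absent from 2,5-dioxopyrrolidin-1-yl, yet in this single pair the number stays within the scatter, so at this position that donor is not required to keep binding at this level. No evidence on the cause of this result is available here.

The compounds shown leave open whether a primary amine, a carboxylic acid or an open-chain acetamide at this ring carbon would also stay within the scatter of compound 1. They also leave open whether the same exchange would give a similar step with other groups elsewhere on the shared core.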